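The source may hold more compounds than are shown below. What is called first, only, known or untested is meant among the compounds shown, and "the series" means these compounds.

Measured so far:
compound 1 `CC/C=C/C(=O)Nc1cc2c(N3CCCc4ccccc43)ncnc2cc1O[C@@H]1CCOC1` — 14300 nM
compound 2 `O=C(/C=C/CN1CCCC1)Nc1cc2c(N3CCc4ccccc43)ncnc2cc1O[C@@H]1CCOC1` — 1510 nM

In a functional assay on PC-3 cells (Homo sapiens) for antiproliferative activity, read by MTT assay, with a stated time of 72 h (on this read-out lower numbers stand for stronger inhibition and higher numbers for weaker inhibition), compound 2 gives 1510 nM, the lowest of the two numbers; compound 1 gives 14300 nM, a gap beyond the usual scatter. Compound 3 `O=C(/C=C/CN1CCCC1)Nc1cc2c(N3CCCc4ccccc43)ncnc2cc1O[C@@H]1CCOC1` carries 1,2,3,4-tetrahydroquinolin-1-yl in place of 2,3-dihydro-1H-indol-1-yl on an aromatic carbon. Among the measured compounds shown here, no measured pair differs in this place alone, and compound 1 differs from compound 3 in the amide as well, so its number cannot be read as this step by itself. The expected step from compound 2 to compound 3 in this assay is a 2.3-fold higher number from compound 2 to compound 3 (0.37 log units; beyond the scatter), a modest rise. Compound 3 is estimated at 3500 nM, within a range from 900 nM to 14000 nM.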

Compound 3, half-maximal inhibitory concentration: 5780 nM
The estimate for compound 3 lay 1.7-fold (0.22 log units) below the measured number; measured number inside the range.
By their numbers in this assay, from the lowest: compound 2; then compound 3; then compound 1.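

In this assay, the six-membered non-aromatic ring of 1,2,3,4-tetrahydroquinolin-1-yl in place of the five-membered ring of 2,3-dihydro-1H-indol-1-yl gives a 3.8-fold higher number from compound 2 to compound 3 (0.58 log units; beyond the scatter) at this aromatic carbon, so this position responds to a one-carbon ring change. With 1,2,3,4-tetrahydroquinolin-1-yl held constant, pyrrolidin-1-yl in place of methyl on the saturated chain carbon gives a 2.5-fold lower number from compound 1 to compound 3 (0.39 log units; beyond the scatter) in the same assay, so the chain also affects the number. No measurement here bears on the cause of either step.

On these data alone, whether morpholin-4-yl on the chain would follow the pyrrolidin-1-yl step remains open. So does the effect of a seven-membered ring at the aromatic carbon.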